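The source may report more compounds than this note shows. Statements on the series, on what has been measured and on what is new or still open speak of the compounds shown alone.

Working notes on the series. Among the compounds with values here, compound 3 `C#CCNc1nc(-c2ccccc2)c(Cc2c(O)ccc3ccccc23)c(=O)[nH]1` gives 130000 nM in a functional assay on RT-112 cells (Homo sapiens) for antiproliferative activity, read by MTT assay, with a stated time of 24 h (a higher number here means a weaker inhibitor, a lower number a stronger inhibitor), the second highest of the three numbers measured so far; compound 2 `CCN(CC)c1nc(-c2ccccc2)c(Cc2c(O)ccc3ccccc23)c(=O)[nH]1` with 155000 nM sits within the scatter of it, whereas compound 1 `CCCCNc1nc(-c2ccccc2)c(Cc2c(O)ccc3ccccc23)c(=O)[nH]1` with 1600 nM lies far below both. Within the data shown here, the only step that touches the same place as the one now considered is an 81-fold higher number from compound 1 to compound 3 (1.91 log units; beyond the scatter); the steps of a 97-fold higher number from compound 1 to compound 2 (1.99 log units; beyond the scatter) and a 1.2-fold lower number from compound 2 to compound 3 (0.08 log units; within the scatter) concern the group on the aromatic carbon and show that two different replacements of the butylamino group both moved the number a long way in the same direction. Compound 4 `O=c1[nH]c(NCCO)nc(-c2ccccc2)c1Cc1c(O)ccc2ccccc12` differs from compound 3 as follows: hydroxymethyl in place of ethynyl on a saturated chain carbon bound to a nitrogen on an aromatic ring. Among the measured compounds shown here, no measured pair exchanges a hydroxymethyl for anything, so the direction of this step rests on the single observation that leaving the propyl of compound 1 cost a large step, and the hydroxyethyl chain is again not that propyl. A modest step down, not beyond what the scatter and this uncertainty allow, is expected, a 2.6-fold lower number from compound 3 to compound 4 (0.41 log units; beyond the scatter). Compound 4 is therefore estimated at 50000 nM in this assay, with a range from 6000 nM to 250000 nM.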

Compound 4, half-maximal inhibitory concentration: 96600 nM
Compound 4: the middle estimate sits 1.9-fold (0.29 log units) below what was measured, within the range that was stated.
By their numbers in this assay, from the lowest: compound 1; then compounds 4, 3 and 2 (each within the scatter of the next).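

Replacing ethynyl with hydroxymethyl at this place on the chain leaves the reading unresolved (a 1.3-fold lower number from compound 3 to compound 4 (0.13 log units; within the scatter)), and the comparison with the diethylamino group reads the same way (a 1.6-fold lower number from compound 2 to compound 4 (0.21 log units; within the scatter)) in this assay. The hydroxyl-bearing chain, which adds a hydrogen-bond donor and acceptor, does not recover the butylamino result (a 60-fold higher number from compound 1 to compound 4 (1.78 log units; beyond the scatter)), making it a third replacement of that group to end up far from compound 1 and level with the other two. No independent measurement bears on why the butylamino compound stands apart.

Going by these compounds, whether a pentylamino chain, or a butylamino chain ending in an amine or a carboxylic acid, would stay near compound 1 remains open. The compounds shown also cannot separate the length of the chain from the identity of its end.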